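Cytotoxicity Limits Across Three Analogues and a Fourth

The compounds below may be only part of what the source reports. "The series", "measured", "known", "first", "only" and "open" are said of these compounds alone.

Compound 1 `O=C(O)c1ccccc1C1CC(c2cc3ccccc3o2)=NN1C(=O)c1ccncc1`: in an ADME assay on Vero cells (Chlorocebus sabaeus) for cytotoxicity, read by MTT assay, with a stated time of 72 h (on this read-out higher numbers stand for weaker inhibition and lower numbers for stronger inhibition), compound 1 gives > 170000 nM, a limit of the assay.
Compound 2 `O=C(c1ccncc1)N1N=C(c2cc3ccccc3o2)CC1c1cccc([N+](=O)[O-])c1`: in this assay compound 2 gives > 240000 nM, again a limit.
Compound 3 `O=C(c1ccncc1)N1N=C(c2cc3ccccc3o2)CC1c1ccccc1Cl`: in this assay compound 3 gives > 210000 nM, also a limit.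

Compound 3 thus stands at the limit of > 210000 nM in this assay, at which 1 of the 3 values shown sits, and no measured number places it relative to the others. The steps that touch it, a step that the two limits leave unreadable from compound 1 to compound 3 and a step that the two limits leave unreadable from compound 2 to compound 3, cannot be read, and neither can a step that the two limits leave unreadable from compound 1 to compound 2; every value sits at a limit, as the limit of > 170000 nM in this assay, at which 1 of the 3 values shown sits, and the limit of > 240000 nM in this assay, at which 1 of the 3 values shown sits, show. The change to compound 4 `O=C(c1ccncc1)N1N=C(c2cc3ccccc3o2)CC1c1ccccc1[N+](=O)[O-]` is nitro in place of chloro on an aromatic carbon. Going by the values given here, none of the measured steps gives a readable size for any change on this ring, so no step beyond the scatter can be foreseen in this assay in either direction. Compound 4 is therefore expected to give 250000 nM, within 100000 nM to 1000000 nM. The expected step that the limit leaves unreadable from compound 3 to compound 4 is an estimate only, most likely ending at another limit.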

Compound 4, half-maximal inhibitory concentration: > 245000 nM
Compound 4 ended at the assay's limit; the forecaster's own chance of this, stated with the estimate: 80%; the middle value does not contradict the limit.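

In this assay compound 4 gives > 245000 nM, which is a limit. Its steps from compound 1, compound 2 and compound 3 therefore cannot be read. The compounds shown leave open whether any of these four differs from another in this assay, and at what concentration any of them would reach half-maximal inhibition.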